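Swapping the aryl group on the sulfonamide nitrogen

The source may hold more compounds than are shown below. What is called first, only, known or untested is meant among the compounds shown, and "the series" means these compounds.

For the measured compounds named here, in a functional assay on MCF7 cells (Homo sapiens) for antiproliferative activity, read by sulforhodamine B assay, with a stated time of 48 h (on this read-out lower numbers stand for stronger inhibition and higher numbers for weaker inhibition), compound 1 `CCc1ccccc1NS(=O)(=O)c1ccc(N2CCNC2=O)cc1` gives 350 nM, and compound 2 `O=C1NCCN1c1ccc(S(=O)(=O)Nc2cccc(Br)c2)cc1` gives 100 nM, the lower of the two numbers so far. Compound 2 therefore stands as the stronger of this pair. The next compound, compound 3 `O=C1NCCN1c1ccc(S(=O)(=O)Nc2ccc(Cl)cc2)cc1`, differs from compound 2 in one place: 4-chlorophenyl in place of 3-bromophenyl on a sulfonamide nitrogen. In words, 4-chlorophenyl stands in place of 3-bromophenyl on a sulfonamide nitrogen.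

Going by the values given here, only one measured step bears on this change: a 3.5-fold lower number from compound 1 to compound 2 (0.54 log units; beyond the scatter). There, 3-bromophenyl replaced 2-ethylphenyl at the same place, and the step was modest but beyond the scatter. Among the compounds with values here, it shows that the group on the sulfonamide nitrogen can shift the number, but no measured compound carries 4-chlorophenyl, so the direction of the next step is poorly fixed. Compound 2 holds the lowest number at 100 nM, so a small loss in this assay is the more likely outcome, and a step much larger than the one measured is not expected. The expected step is a 1.8-fold higher number from compound 2 to compound 3 (0.26 log units; within the scatter). For compound 3 the estimated value is 180 nM, with an expected range of 60 nM to 550 nM.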

Compound 3, half-maximal inhibitory concentration: 170 nM
Compound 3: the middle estimate sits 1.1-fold (0.02 log units) above what was measured, within the range that was stated.
By their numbers in this assay, from the lowest: compounds 2 and 3 (each within the scatter of the next); then compound 1.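

In this assay the step shows a 1.7-fold higher number from compound 2 to compound 3 (0.23 log units; within the scatter), so 4-chlorophenyl and 3-bromophenyl on a sulfonamide nitrogen cannot be told apart at this position, even though the halogen and its printed ring position both differ. Against 2-ethylphenyl, the same replacement gives a 2.1-fold lower number from compound 1 to compound 3 (0.31 log units; beyond the scatter), so both halophenyl compounds now lie beyond the scatter from compound 1, although the two compounds are not enough to make a general rule and compound 1 is the only non-halogenated comparison. No measured information here accounts for these numbers.

On these data alone, the two halophenyl compounds change both the halogen and its position together, so the separate contribution of each remains open; 3-chlorophenyl and 4-bromophenyl would be the pair needed to separate them. Also open, as far as these compounds go, is how far this position tolerates a different kind of group, such as an aminophenyl, a carboxyphenyl or a plain alkyl chain in place of the aryl ring, and whether any such group would move the number outside the narrow span seen so far.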